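The compounds below may be only part of what the source reports. "The series", "measured", "known", "first", "only" and "open" are said of these compounds alone.

Measured so far in an ADME assay on HaCaT cells (Homo sapiens) for cytotoxicity, read by MTT assay, with a stated time of 72 h; a lower number here means a stronger inhibitor, a higher number a weaker inhibitor:
compound 1 `CCCCCCCCNC1=CC(=O)C(C(C)(C)C)=CC1=O`, > 100000 nM
compound 2 `CCCCCCCCNC1=CC(=O)C=C(C[C@]2(C)[C@@H](C)CC[C@]3(C)C(C)=CCC[C@@H]23)C1=O`, 17000 nM
compound 3 `CCCCNC1=CC(=O)C=C(C(C)(C)C)C1=O`, 11000 nM

The value of compound 1 is the limit of > 100000 nM in this assay, at which 1 of the 3 values shown sits, a limit of this assay and not a number. Of the two numbers, compound 2 holds the higher one, yet its gap to compound 3 lies within the scatter, so the two are not placed in order. Compound 4 `CCCCNC1=CC(=O)C=C(C[C@]2(C)[C@@H](C)CC[C@]3(C)C(C)=CCC[C@@H]23)C1=O` differs from compound 2 by hydrogen in place of butyl on a saturated chain carbon, four bonds along the chain from an amine nitrogen. Compound 3 also carries a butyl chain and gives a number in this assay. On that basis the step in this assay from compound 2 to compound 4 is expected to lower the number, though not clearly beyond the scatter. Compound 4 is expected at 10000 nM, with a range from 3000 nM to 35000 nM. That estimate means an expected step of a 1.7-fold lower number from compound 2 to compound 4 (0.23 log units; within the scatter).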

Compound 4, half-maximal inhibitory concentration: 16000 nM
Compound 4: middle estimate off by 1.6-fold (0.20 log units), on the low side; low and high end bracket the measured number.
By their numbers in this assay, from the lowest: compounds 3, 4 and 2 (each within the scatter of the next). At a limit, above all of these: compound 1.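

In this assay, going by these compounds alone, hydrogen in place of butyl on a saturated chain carbon, four bonds along the chain from an amine nitrogen, gives a 1.1-fold lower number from compound 2 to compound 4 (0.03 log units; within the scatter) and so provides the first step that can be read at this position. On the core of compound 2, the butyl portion can therefore go without a change beyond the scatter. Nothing at hand gives a cause for this result.

The compounds shown leave open whether a longer chain, or an amine or a carboxylic acid at this position, would also stay within the scatter of compound 2.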